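The source may hold more compounds than are shown below. What is called first, only, known or untested is meant among the compounds shown, and "the series" means these compounds.

Compound 3 `N#Cc1ccccc1COc1ccccc1C(=O)Nc1cccnc1` gives the highest number of the three in this assay, 31800 nM; compound 1 `Cc1ccccc1COc1ccccc1C(=O)Nc1cccnc1` gives 1500 nM and compound 2 `O=C(Nc1cccnc1)c1ccccc1OCc1ccccc1C(F)(F)F` gives 2100 nM in an assay on lysate for inhibition of phosphatidylcholine:ceramide cholinephosphotransferase 2 (Homo sapiens), read by HPLC, with stated times of 30 min and 2 h; on this read-out lower numbers stand for stronger inhibition and higher numbers for weaker inhibition. The two measured steps that end at compound 3 are both large and both run toward weaker inhibition: a 21-fold higher number from compound 1 to compound 3 (1.33 log units; beyond the scatter) and a 15-fold higher number from compound 2 to compound 3 (1.18 log units; beyond the scatter). Compound 4 `O=C(Nc1cccnc1)c1ccccc1OCc1ccccc1OCCCCCCCl` differs from compound 3 by (6-chlorohexyl)oxy in place of cyano on an aromatic carbon. Going by the values given here, no measured step exchanges cyano for an alkoxy chain, so the size of this change is uncertain. The cyano analogue stands far apart from the methyl and trifluoromethyl analogues, and a return toward their range is expected: a 13-fold lower number from compound 3 to compound 4 (1.10 log units; beyond the scatter). Compound 4 is therefore estimated at 2500 nM, with a range from 500 nM to 12000 nM.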

Compound 4, half-maximal inhibitory concentration: 470 nM
Compound 4: the middle estimate sits 5.3-fold (0.73 log units) above what was measured; measured number below the stated range.
By their numbers in this assay, from the lowest: compound 4; then compounds 1 and 2 (each within the scatter of the next); then compound 3.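

This position, ortho to a large group, takes the far longer (6-chlorohexyl)oxy with a gain rather than a loss: a 68-fold lower number from compound 3 to compound 4 (1.83 log units; beyond the scatter) and a 4.5-fold lower number from compound 2 to compound 4 (0.65 log units; beyond the scatter) and a 3.2-fold lower number from compound 1 to compound 4 (0.50 log units; beyond the scatter). Compound 4 is thus the strongest inhibitor of the four, and the first substituent here to improve beyond the scatter on methyl and trifluoromethyl. Nothing at hand accounts for this gain.

Open, from the compounds shown here alone, is whether the gain belongs to the ether oxygen, the chain length or the terminal chlorine. A methoxy group, a plain hexyloxy chain or a chain ending in an amine would separate these.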